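Chloro in Place of Methoxy on a Shared Core

A few compounds are considered here, and "the series" means these few. Any claim that something is new, unique, unknown or untested is made for them only; others in the source may bear on it.

Compound 1 `COc1ccc(N2CCN(CC(=O)N3CCN(c4nnc(-c5ccccc5)c(-c5ccccc5)n4)CC3)CC2)cc1` in a functional assay on MCF7 cells (Homo sapiens) for cytotoxicity, read by MTT assay, with a stated time of 24 h (on this read-out lower numbers stand for stronger inhibition and higher numbers for weaker inhibition), gives > 910000 nM, which is a limit of the assay. Compound 2 `O=C(CN1CCN(c2ccc(Cl)cc2)CC1)N1CCN(c2nnc(-c3ccccc3)c(-c3ccccc3)n2)CC1` gives 56300 nM. Compound 3 `COc1ccccc1N1CCN(CC(=O)N2CCN(c3nnc(-c4ccc(C)cc4)c(-c4ccc(C)cc4)n3)CC2)CC1` gives 59400 nM.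

Compound 2 arises from compound 1 by chloro in place of methoxy on an aromatic carbon, and this gave an at least 16-fold lower number from compound 1 to compound 2 (1.20 log units; beyond the scatter); since compound 1 sits at the limit (the limit of > 910000 nM in this assay, at which 1 of the 3 values shown sits), the true size of that step is not known. Compound 3 and compound 2 lie within the scatter of each other. How the core of compound 3 differs from that of compound 1 is not broken down here.

Compound 4 `Cc1ccc(-c2nnc(N3CCN(C(=O)CN4CCN(c5ccccc5Cl)CC4)CC3)nc2-c2ccc(C)cc2)cc1` arises from compound 3 by chloro in place of methoxy on an aromatic carbon. This is the same kind of change, but the place differs: para to a large group in the first case, ortho to a large group here. Compound 4 is estimated at 40000 nM, between 10000 nM and 150000 nM. The expected step of a 1.5-fold lower number from compound 3 to compound 4 (0.17 log units; within the scatter) is modest, resting on compound 2 at 56300 nM and on the step of an at least 16-fold lower number from compound 1 to compound 2 (1.20 log units; beyond the scatter).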

Compound 4, half-maximal inhibitory concentration: 859000 nM
Estimate against measurement, compound 4: 21-fold (1.33 log units) below; measured number outside the range, above it.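

In this assay chloro in place of methoxy gave a 14-fold higher number from compound 3 to compound 4 (1.16 log units; beyond the scatter) and so did not carry over from the earlier core, with the two steps running in opposite directions: the same change on two cores in this assay, an at least 16-fold lower number (1.20 log units; beyond the scatter) from compound 1 to compound 2 and a 14-fold higher number (1.16 log units; beyond the scatter) from compound 3 to compound 4, at least 230-fold (2.36 log units) apart, beyond the scatter of two such steps.

This does not show whether the core or the place on the ring decides the outcome: the two pairs differ in both, and the compounds shown do not separate them. As far as these compounds go, the earlier step also rests on a limit, so its true size stays unknown: the limit of > 910000 nM in this assay, at which 1 of the 4 values shown sits.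

The compounds shown leave open how 2-chlorophenyl would behave on the core of compound 1. They also leave open how a fluoro or a nitrile would compare with chloro on either core.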